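Swapping Cyclopropyl for Ethyl on a Urea Nitrogen

The source may hold more compounds than are shown below. What is called first, only, known or untested is meant among the compounds shown, and "the series" means these compounds.

Of the compounds shown here, two with a shared core have been tested so far in a functional assay on LNCaP cells (Homo sapiens) for cytotoxicity; a lower number here means a stronger inhibitor, a higher number a weaker inhibitor. Compound 1 `CCn1ncc2c(N3CC4CCC(C3)O4)nc(-c3ccc(NC(=O)NC)cc3)nc21` gives 70 nM in this assay. Compound 2 `O=C(Nc1ccc(-c2nc(N3CC4CCC(C3)O4)c3cnn(C4CCC5(CC4)OCCO5)c3n2)cc1)NC1CC1` gives 2 nM, the lowest of the two numbers; the gap to compound 1 lies beyond the scatter, but the two structures differ in more than one place, so their values can only be set side by side without tracing the gap to a single change.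

Compound 3 `CCNC(=O)Nc1ccc(-c2nc(N3CC4CCC(C3)O4)c3cnn(C4CCC5(CC4)OCCO5)c3n2)cc1` keeps everything of compound 2 but one group: ethyl in place of cyclopropyl on an amide-type nitrogen. Both the group that leaves and the group that enters are made only of carbon, with no hydrogen-bond donors or acceptors, and the rest of the molecule is untouched. For the measured compounds named here, with no measured step that isolates this kind of change, the expectation rests on the closeness of the two groups: compound 3 is expected to sit near compound 2, with a step of a 1.8-fold higher number from compound 2 to compound 3 (0.24 log units; within the scatter) that stays within or only just beyond the scatter, if anything toward a slightly higher number. Compound 3 is therefore estimated at 3.5 nM, within a range from 1.5 nM to 9 nM.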

Compound 3, half-maximal inhibitory concentration: 1 nM
For compound 3 the middle estimate is 3.5-fold (0.54 log units) above the measured one; measured number below the stated range.
By their numbers in this assay, from the lowest: compounds 3 and 2 (each within the scatter of the next); then compound 1.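

In this assay the swap of cyclopropyl for ethyl on the amide-type nitrogen is a 2.0-fold lower number from compound 2 to compound 3 (0.30 log units; within the scatter), so the two groups cannot be told apart in this read-out. For the compounds shown here, this is the first step in the set that isolates a single change, and it shows that, for this pair, opening the three-membered ring and giving up one carbon leaves the number unchanged within the usual noise: the cyclopropyl ring is not required here for a value as low as that of compound 2. No measurement at hand offers an explanation for why the two groups read alike.

On these data alone, both groups are made only of carbon, so it remains open whether a longer chain such as butyl, or a group carrying an amine or a carboxylic acid, would be tolerated on this nitrogen in the same way. As far as these compounds go, compound 1 differs from compound 3 in more than one place, so it also remains open how much this urea substituent contributes on the core of compound 1.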